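The source may report more compounds than this note shows. Statements on the series, on what has been measured and on what is new or still open speak of the compounds shown alone.

Compound 1 `NC(=O)[C@@H]1CC[C@H](c2ccc(OCc3ccc(F)cc3)cc2)N1` stands highest of the two numbers measured in an ADME assay on the whole organism (blood, Rattus norvegicus) for pharmacokinetics, at a dose of 0.5 mg/kg by the intravenous route (on this read-out lower numbers stand for slow clearance and higher numbers for fast clearance), where compound 1 gives 91 mL/min/kg. Compound 2 `NC(=O)[C@@H]1CC[C@H](c2ccc(Oc3ccccc3)cc2)N1` gives 40 mL/min/kg in this assay, a gap beyond the usual scatter. Compound 3 `N#Cc1ccccc1COc1ccc([C@H]2CC[C@@H](C(N)=O)N2)cc1` differs from compound 1 in one place: 2-cyanophenyl in place of 4-fluorophenyl on a saturated chain carbon bound to an oxygen on an aromatic ring. Within the data shown here, no measured pair shows this change, so its effect is unknown; the expected step in this assay is a 1.3-fold lower number from compound 1 to compound 3 (0.11 log units; within the scatter), a slight drift toward slower clearance that stays within the scatter. Compound 3 is therefore expected to give about 70 mL/min/kg in this assay, between 35 mL/min/kg and 140 mL/min/kg.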

Compound 3, clearance: 37 mL/min/kg
Compound 3: the middle estimate sits 1.9-fold (0.28 log units) above what was measured, within the range that was stated.
By their numbers in this assay, from the lowest: compounds 3 and 2 (each within the scatter of the next); then compound 1.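

In this assay, among these compounds, 2-cyanophenyl in place of 4-fluorophenyl gives a 2.5-fold lower number from compound 1 to compound 3 (0.39 log units; beyond the scatter) and so brings the first single-place comparison at this position. It shows that the aryl group on the saturated chain carbon bound to an oxygen on an aromatic ring can shift clearance beyond the scatter with the rest of the molecule unchanged. No measurement available here accounts for the step. Going by these compounds, whether the step belongs to the nitrile or to the loss of the fluorine remains open. So does how a plain phenyl or a methoxy-bearing phenyl would read at this place.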